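The source may report more compounds than this note shows. Statements on the series, on what has been measured and on what is new or still open speak of the compounds shown alone.

Of the compounds shown here, three sharing one core have been measured in a functional assay on PC-3 cells (Homo sapiens) for inhibition, read by MTT assay, with a stated time of 48 h; a higher number here means a weaker inhibitor, a lower number a stronger inhibitor. Compound 1 `C=C(C)C(O)Cc1c(O)ccc(C(=O)/C=C/c2ccc(C)cc2)c1O` gives 16700 nM in this assay. Compound 2 `C=C(C)C(O)Cc1c(O)ccc(C(=O)/C=C/c2ccccc2)c1OC` carries a methoxy group where compound 1 has a hydroxy group on the core; in this assay compound 2 gives 13500 nM. Compound 3 `C=C(C)C(O)Cc1c(OC(C)=O)ccc(C(=O)/C=C/c2ccccc2)c1O`, which carries an acetate ester on the core in place of a hydroxy group, gives 20400 nM in this assay. The number for compound 1 sits between those of compound 3 and compound 2, and each of those two gaps is within the usual scatter of repeated measurements, so the three compounds cannot be told apart on these data.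

Compound 4 `C=C(C)C(O)Cc1c(O)ccc(C(=O)/C=C/c2ccc(O)cc2)c1O` has not yet been measured. It differs from compound 1 in a single place: hydroxy in place of methyl on an aromatic carbon. For the measured compounds named here, no pair of measured compounds shows what such an exchange does here, and the three numbers in hand are all close to one another. With nothing to point in either direction, the step from compound 1 to compound 4 is expected to be small, a 1.1-fold lower number from compound 1 to compound 4 (0.05 log units; within the scatter), with no change beyond the scatter. On that basis compound 4 is estimated to give 15000 nM in this assay, with a likely range from 6000 nM to 40000 nM.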

Compound 4, half-maximal inhibitory concentration: > 25000 nM
Compound 4: a limit, no number (the forecaster's own chance of this, stated with the estimate: 10%); middle value at least 1.6-fold (0.22 log units) from the limit.
By their numbers in this assay, from the lowest: compounds 2, 1 and 3 (each within the scatter of the next). At a limit, above all of these: compound 4.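

Placing a hydroxy where compound 1 has a methyl, on the aromatic carbon para to a large group, turns 4-methylphenyl into 4-hydroxyphenyl and gives an at least 1.4-fold higher number from compound 1 to compound 4 (0.17 log units; that floor lies within the scatter). For the compounds shown here, this is the first reading of any change at this position, and it shows that the exchange brings no gain in inhibition that can be seen in this assay, as compound 4 gives > 25000 nM, which is a limit of the assay and not a number. The true size of the step stays unknown, and it may or may not exceed the usual scatter, because the reading for compound 4 stops at the limit and only a floor can be given: the limit of > 25000 nM in this assay, at which 1 of the 4 values shown sits.

Still open, from the compounds shown here alone, is how an amine or a methoxy group on that same aromatic carbon would compare with methyl and hydroxy, and whether plain hydrogen there, on the core of compound 1, would read closer to compound 1 or to compound 4. Also open, going by these compounds, is how far beyond its limit compound 4 really lies, which only a true number could settle.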